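A few compounds are considered here, and "the series" means these few. Any claim that something is new, unique, unknown or untested is made for them only; others in the source may bear on it.

Compound 1 `Cc1cc(NC(=O)Nc2cccc(C(N)=O)c2)c2ccccc2n1` is a urea whose outer ring carries a carbamoyl group, and in an ADME assay for permeability, using PAMPA, at pH 7.4 (a lower number here means that the compound crosses the layer more slowly, a higher number that the compound crosses the layer faster), compound 1 gives 2 10^-6 cm/s. Compound 2 `Cc1cc(NC(=O)Nc2ccc(C(F)(F)F)cc2)c2ccccc2n1` carries a trifluoromethyl group on that ring instead; in this assay compound 2 gives 2 10^-6 cm/s, level with compound 1 within the scatter. Compound 3 `Cc1cc(NC(=O)Nc2cccc(Cl)c2)c2ccccc2n1` is not yet measured. From compound 1 to compound 3 the change is chloro in place of carbamoyl on an aromatic carbon. Among the compounds with values here, no measured pair shows this swap directly, and because compound 2 gives 2 10^-6 cm/s with a different group in place of the carbamoyl, the expected step is only a small rise, a 1.5-fold higher number from compound 1 to compound 3 (0.18 log units; within the scatter). Compound 3 is expected at 3 10^-6 cm/s, between 1 10^-6 cm/s and 8 10^-6 cm/s.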

Compound 3, apparent permeability: 566 10^-6 cm/s
For compound 3 the middle estimate is 190-fold (2.28 log units) below the measured one; the measured number lies above the stated range.
By their numbers in this assay, from the lowest: compounds 1 and 2 (each within the scatter of the next); then compound 3.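

Putting chloro in place of carbamoyl on this aromatic carbon gives, in this assay, a 280-fold higher number from compound 1 to compound 3 (2.45 log units; beyond the scatter), a large step. So a single small group at this position can change the read-out greatly, which compounds 1 and 2 gave no hint of. Nothing measured here explains the step.

Going by these compounds, it remains open whether this rise is specific to chloro or would also come with another group here, such as methyl or a nitrile. The same goes for a carbamoyl or chloro placed elsewhere on that ring.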